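Cell Tolerability Across Three Measured Compounds and One Estimate

The source may hold more compounds than are shown below. What is called first, only, known or untested is meant among the compounds shown, and "the series" means these compounds.

Compound 1 `CC1(C)OC(=O)C2(C(=O)O1)[C@@H](c1ccco1)CC(=O)C[C@H]2c1ccccc1`: in an ADME assay on MT2 cells (Homo sapiens) for cytotoxicity (a higher number here means that more compound is tolerated, a lower number that less compound is tolerated), compound 1 gives > 111000 nM, a limit of the assay.
Compound 2 `CC1(C)OC(=O)C2(C(=O)O1)[C@@H](c1ccco1)CC(=O)C[C@H]2c1ccc(F)cc1`: in this assay compound 2 gives > 111000 nM, again a limit.
Compound 3 `CC1(C)OC(=O)C2(C(=O)O1)[C@@H](c1ccco1)CC(=O)C[C@H]2c1ccccc1Cl`: in this assay compound 3 gives > 111000 nM, also a limit.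

Going by the values given here, compound 3 therefore stands at the limit of > 111000 nM in this assay, at which 3 of the 3 values shown sit, and no measured compound stands anywhere else. The change leading to compound 4 `COc1cccc([C@@H]2CC(=O)C[C@H](c3ccco3)C23C(=O)OC(C)(C)OC3=O)c1OC` is 2,3-dimethoxyphenyl in place of 2-chlorophenyl on a saturated ring carbon. Among the compounds with values here, three measured steps exist, a step that the two limits leave unreadable from compound 1 to compound 2, a step that the two limits leave unreadable from compound 1 to compound 3 and a step that the two limits leave unreadable from compound 2 to compound 3, and none of them has a readable size; every measured value is a limit, so no step shows a direction in which a change on this saturated ring carbon moves the read-out. Nothing in the measured compounds points to compound 4 leaving the limit. In this assay compound 4 is expected to give 150000 nM, with a range from 50000 nM to 450000 nM, most probably reported once more as a limit. The expected step is estimated as a step that the limit leaves unreadable from compound 3 to compound 4, none beyond the scatter.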

Compound 4, half-maximal cytotoxic concentration: > 111000 nM
Compound 4 was reported as a limit (the forecaster's own chance of this, stated with the estimate: 85%); the middle value is on the limit's open side.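

Compound 4 is also reported only as a limit, so its steps from compound 1, compound 2 and compound 3 cannot be read: the limit of > 111000 nM in this assay, at which 4 of the 4 values shown sit. The compounds shown leave open whether any change on this saturated ring carbon moves the half-maximal cytotoxic concentration in this assay at all.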